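This account rests on a few compounds, and the source may have more. Where it says the series, first, only, none or still open, it means among the compounds named here.

Measured so far:
- compound 1 `O=C(O)c1ccc2cc(N3CCC4(C=C(c5c(-c6c(Cl)cc(F)cc6Cl)noc5C5CC5)C4)CC3)ccc2n1`; in an ADME assay on microsomes from liver (Homo sapiens) for metabolic stability (on this read-out lower numbers stand for a shorter-lived compound and higher numbers for a longer-lived compound), compound 1 gives 1.67 h
- compound 2 `O=C(O)c1cc(F)c2nc(N3CC4C(/C=C/c5c(-c6c(Cl)cccc6Cl)noc5C5CC5)C4C3)sc2c1`; in this assay compound 2 gives 0.717 h
- compound 3 `O=C(O)c1cc(F)c2nc(N3CCC4(C=C(c5c(-c6c(Cl)cccc6Cl)noc5C5CC5)C4)CC3)sc2c1`; in this assay compound 3 gives 0.85 h

All three values lie within the usual scatter of one another, so no order can be read among them. Compound 3 sits closer to compound 2 than to compound 1 on the numbers, and nothing further is separated here.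

The next compound in the series is compound 4 `O=C(O)c1cc(F)c2nc(N3CCC4(C=C(c5c(-c6ccccc6OC(F)(F)F)noc5C5CC5)C4)CC3)sc2c1`. It differs from compound 3 in one place: 2-(trifluoromethoxy)phenyl in place of 2,6-dichlorophenyl on an aromatic carbon. Within the data shown here, no pair of measured compounds differs in a matching way, so the size of this step in this assay has no direct precedent among the numbers in hand. With nothing to anchor a shift in either direction, the step from compound 3 to compound 4 is expected to stay within the scatter, as a 1.1-fold lower number from compound 3 to compound 4 (0.03 log units; within the scatter).

Compound 4 is therefore estimated at 0.8 h in this assay, with a range from 0.4 h to 1.6 h.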

Compound 4, half-life: 1.62 h
Compound 4: the middle estimate sits 2.0-fold (0.31 log units) below what was measured, and the stated range ends below it.
By their numbers in this assay, from the lowest: compounds 2, 3, 4 and 1 (each within the scatter of the next, the first and the last beyond it).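

In this assay, placing 2-(trifluoromethoxy)phenyl in place of 2,6-dichlorophenyl on the aromatic carbon of the five-membered ring gives a 1.9-fold higher number from compound 3 to compound 4 (0.28 log units; within the scatter) and is the only step among these compounds that differs in one place. This position therefore takes an entering group with more heavy atoms and one hydrogen-bond acceptor, with no shift that can be separated from the scatter. Nothing at hand bears on what lies behind this step.

As far as these compounds go, whether the same reading holds for other groups here remains open: 2-chlorophenyl or 2-methoxyphenyl in this place would show whether it extends beyond these two groups. Also open, from the compounds shown here alone, is whether this change gives a comparable step on the core of compound 1 or the core of compound 2.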